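The compounds below may be only part of what the source reports. "The series", "measured", "known", "first", "only" and "open" are said of these compounds alone.

Compound 1 `CN(C)CN1C(=O)C(=O)c2c(Br)cccc21` is measured in a functional assay on MDA-MB-231 cells (Homo sapiens) for cytotoxicity, read by sulforhodamine B assay, with a stated time of 48 h (a higher number here means a weaker inhibitor of growth, a lower number a stronger inhibitor of growth), where compound 1 gives 93700 nM, the highest of the two numbers recorded; its nearest neighbour is compound 2 `CCN(CC)CN1C(=O)C(=O)c2c(Br)cccc21`, which in this assay gives 20200 nM, a step of a 4.6-fold lower number from compound 1 to compound 2 (0.67 log units; beyond the scatter). Compound 3 `CN(C)CN1C(=O)C(=O)c2ccccc21` differs from compound 1 by hydrogen in place of bromo on an aromatic carbon. Among the measured compounds shown here, the only measured step alters the amine on the chain, not the aromatic ring, so no step bears directly on this change. He therefore expects a step in this assay from compound 1 to compound 3 of about a 1.4-fold higher number from compound 1 to compound 3 (0.14 log units; within the scatter), not beyond the scatter. For compound 3 he estimates 130000 nM, within 50000 nM to 350000 nM.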

Compound 3, concentration for 50% growth inhibition: 65600 nM
The estimate for compound 3 lay 2.0-fold (0.30 log units) above the measured number; low and high end bracket the measured number.
By their numbers in this assay, from the lowest: compound 2; then compounds 3 and 1 (each within the scatter of the next).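

In this assay the change gives a 1.4-fold lower number from compound 1 to compound 3 (0.15 log units; within the scatter), so with the dimethylamino chain in place, compound 1 and compound 3 cannot be told apart when hydrogen stands in place of bromo on this aromatic carbon. On these numbers the bromo is not required for the reading of compound 1, whereas the change of amine on the chain gave a step beyond the scatter. No available data explain this result. Still open, on these data alone, is whether hydrogen in place of bromo would read the same in compound 2, and whether chloro, methoxy or a nitrile on this carbon would give a step beyond the scatter.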